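This account rests on a few compounds, and the source may have more. Where it says the series, first, only, none or still open, it means among the compounds named here.

Working notes on the series. Two compounds share the same core, a diaryl sulfide carrying two methoxy groups on the phenyl side and a fused bicyclic heteroaryl on the other. Compound 1 `COc1ccc(OC)c(Sc2ccc3nnc(-c4ccsn4)n3n2)c1` bears an isothiazolyl group on the fused ring; in an assay on isolated protein for inhibition of Leucine-rich repeat serine/threonine-protein kinase 2 (Homo sapiens), in the presence of a further agent that is not named here (a lower number here means a stronger inhibitor, a higher number a weaker inhibitor), compound 1 gives 91 nM. Compound 2 `COc1ccc(OC)c(Sc2ccc3ncc(-c4cnn(C)c4)n3n2)c1` instead bears a 1-methyl-1H-pyrazol-4-yl group; in this assay compound 2 gives 69 nM. On the numbers at hand compound 2 holds the lower of the two values, yet the gap to compound 1 lies within the usual scatter, so the two stand on a par for present purposes.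

Compound 3 `COc1ccc(OC)c(Sc2ccc3nc(C)c(-c4cnn(C)c4)n3n2)c1` is the next candidate. It keeps the framework of compound 2 and differs in one place: methyl in place of hydrogen on an aromatic carbon. Within the data shown here, no measured pair in the set shows what such an addition does, so there is no step to lean on. The default expectation is a change that stays within the scatter, with no direction preferred. The estimate for compound 3 in this assay is therefore 70 nM, with a range from 25 nM to 200 nM, which amounts to an expected step of a 1.0-fold higher number from compound 2 to compound 3 (0.01 log units; within the scatter).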

Compound 3, half-maximal inhibitory concentration: 115 nM
Beside the measured number, compound 3's estimate is 1.6-fold (0.22 log units) below it, within the range that was stated.
By their numbers in this assay, from the lowest: compounds 2, 1 and 3 (each within the scatter of the next).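

The aromatic carbon of the five-membered aromatic ring with 2 nitrogen, next to the ring nitrogen and next to the ring atom that bears the 1-methyl-1H-pyrazol-4-yl group, now has its first reading: in this assay, methyl in place of hydrogen gives a 1.7-fold higher number from compound 2 to compound 3 (0.22 log units; within the scatter). On this single pair, the position accepts methyl with no change that can be told from the scatter, so hydrogen and methyl stand on a par here and neither can be preferred on these numbers. No measurement at hand offers an explanation for this reading, or shows how the added methyl relates to the behaviour of the compound in the assay.

Going by these compounds, whether an amine, a carboxylic acid or a longer chain such as propyl on this same carbon would stay on a par with hydrogen and methyl remains open, as one small group says little about the room for larger or charged ones. Also open, on these data alone, is whether methyl at this carbon reads the same once the 1-methyl-1H-pyrazol-4-yl group gives way to another group.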